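The compounds below may be only part of what the source reports. "The series", "measured", "known", "first", "only" and "open" are said of these compounds alone.

Measured compounds:
compound 1 `C=CCNC(=S)NS(=O)(=O)c1ccc(-n2nc(C(=O)O)cc2C)cc1`: -6%
compound 2 `Cc1cc(C(=O)O)nn1-c1ccc(S(=O)(=O)NC(=O)NCc2ccccc2)cc1`: 0%
compound 3 `CCNC(=S)NS(=O)(=O)c1ccc(-n2nc(C(=O)O)cc2C)cc1`: -2%

All three numbers come from a functional assay on the whole organism (blood, strain albino) with Mus musculus as the target, with stated times of 6 days and 4 h, at a dose of 0.4 mmol/kg by the oral route; a lower number here means less inhibition, a higher number more inhibition at the dose given (going by the name of the read-out). Compound 3 stands second highest of the three; its nearest neighbour is compound 2 and its furthest is compound 1, both within the usual scatter, so no order can be read among them.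

Compound 4 `CCNC(=O)NS(=O)(=O)c1ccc(-n2nc(C(=O)O)cc2C)cc1` differs from compound 3 by a group of 5 heavy atoms (3 carbon, 1 nitrogen, 1 oxygen; no ring) in place of a group of 5 heavy atoms (3 carbon, 1 nitrogen, 1 sulfur; no ring), on a sulfonamide nitrogen. Among the measured compounds shown here, the only single-place step measured so far is a number 4 percentage points higher from compound 1 to compound 3 (within the scatter), which concerns the chain and not the exchange on the sulfonamide nitrogen. For the measured compounds named here, compound 2 carries an ethylcarbamoyl-like arrangement but also a different chain, so no step is computed for that pair; its value and that of compound 3 lie within the scatter of each other. Nothing therefore points to a step beyond the scatter, and the expected change is a number 2 percentage points higher from compound 3 to compound 4 (within the scatter). Compound 4 is estimated at 0%, with a range from -10% to 8%.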

Compound 4, a percentage reported as inhibition, in the whole organism at one dose (the size of the read-out at that dose, not a potency): 0%
For compound 4 middle estimate and measured number coincide at the digits printed, within the range that was stated.
By their numbers in this assay, from the lowest: compounds 1, 3, 2 and 4 (each within the scatter of the next).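

In this assay, ethylcarbamoyl on the sulfonamide nitrogen in place of the sulfur-containing group gives a number 2 percentage points higher from compound 3 to compound 4 (within the scatter), so the exchange of sulfur for oxygen at this position is not separated from the scatter. The other exchanges are not separated either: methyl in place of phenyl gives no change at the digits printed from compound 2 to compound 4 (within the scatter), and the wider exchange on the same nitrogen gives a number 6 percentage points higher from compound 1 to compound 4 (within the scatter). No supporting measurement bears on this result.

All four compounds remain close together at this single dose, so this comparison does not establish which part of the structure can move the read-out. From the compounds shown here alone, a longer chain such as butyl on the ethylcarbamoyl nitrogen, or a methyl ester in place of the carboxylic acid, remains open.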